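This account rests on a few compounds, and the source may have more. Where it says the series, first, only, none or still open, it means among the compounds named here.

Measured in a functional assay on A2780 cells (Homo sapiens) for inhibition, read by sulforhodamine B assay, with a stated time of 72 h; on this read-out higher numbers stand for weaker inhibition and lower numbers for stronger inhibition:
- compound 1 `O=C(NCc1ccc(S(=O)(=O)c2cccc(C(F)(F)F)c2)cc1)c1cc2cnccc2[nH]1`: 3 nM
- compound 2 `O=C(NCc1ccc(S(=O)(=O)N2CCCCC2)cc1)c1cnc2nccn2c1`: 130 nM
- compound 3 `O=C(NCc1ccc(S(=O)(=O)c2cccc(C(F)(F)F)c2)cc1)c1cnc2nccn2c1`: 2 nM

On these numbers, compound 3 cannot be told apart from compound 1, and both sit far under compound 2. The next molecule is compound 4 `O=C(NCc1ccc(S(=O)(=O)c2cccc(C(F)(F)F)c2)cc1)c1cc2ccncc2s1`, which keeps the rest of compound 3 and alters only the two-ring group on the carbonyl carbon: a group of 9 heavy atoms (7 carbon, 1 nitrogen, 1 sulfur; one five-membered aromatic ring with 1 hetero atom, one six-membered aromatic ring with 1 hetero atom) in place of a group of 9 heavy atoms (6 carbon, 3 nitrogen; one five-membered aromatic ring with 2 hetero atoms, one six-membered aromatic ring with 2 hetero atoms), on a carbonyl carbon.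

Within the data shown here, two measured steps bear on this change. The closer one is a 1.5-fold lower number from compound 1 to compound 3 (0.18 log units; within the scatter). It also exchanged one two-ring group for another at this same place, and the number barely moved. Among the measured compounds shown here, that is a single example, however, and no measured compound yet carries the sulfur-containing group of compound 4. The other step, a 65-fold lower number from compound 2 to compound 3 (1.81 log units; beyond the scatter), shows that large jumps do occur among these compounds. It happened at the sulfonyl sulfur, though, and compound 4 keeps the 3-(trifluoromethyl)phenyl found there in compound 3, so it says little about this swap.

A small change is therefore expected, with no clear move beyond the scatter and some allowance for a higher number: the estimated step is a 2.0-fold higher number from compound 3 to compound 4 (0.30 log units; within the scatter). For compound 4 the expected value is 4 nM, with an estimated range from 1 nM to 20 nM.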

Compound 4, half-maximal inhibitory concentration: 1 nM
Compound 4: the middle estimate sits 4.0-fold (0.60 log units) above what was measured, and the stated range covers the measured number.
By their numbers in this assay, from the lowest: compounds 4, 3 and 1 (each within the scatter of the next, the first and the last beyond it); then compound 2.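

In this assay, the place on the carbonyl carbon now tolerates a sulfur-containing two-ring group: with a 2.0-fold lower number from compound 3 to compound 4 (0.30 log units; within the scatter), compound 4 cannot be told apart from compound 3, so trading nitrogen atoms for carbon and sulfur in this group costs nothing measurable here. Among these compounds, the comparison with the other two-ring group gives the first step at this place that clears the scatter, a 3.0-fold lower number from compound 1 to compound 4 (0.48 log units; beyond the scatter), although it is only modest and compound 3 cannot be separated from either of the other two. Nothing at hand accounts for this small separation.

From the compounds shown here alone, all three two-ring groups compared here sit with 3-(trifluoromethyl)phenyl on the sulfonyl sulfur, so it remains open whether the sulfur-containing group would hold its number with piperidin-1-yl there, the group that accompanies the much higher number of compound 2. Also open, going by these compounds, is how far this place stays tolerant, for instance whether a single ring such as pyridine, or a two-ring group carrying an added amine or carboxylic acid, would keep the number this low.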